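Methoxy in place of fluoro on the shared core

The compounds below may be only part of what the source reports. "The series", "measured", "known", "first", "only" and "open" are said of these compounds alone.

Compound 1, `Clc1cccc(Nc2n[nH]c3ccccc23)c1`, gives 42% in a functional assay on the whole organism (liver) for inhibition, with Mus musculus as the target, with a stated time of 2.5 h, at a dose of 30 mg/kg by the oral route; a lower number here means less inhibition, a higher number more inhibition at the dose given (going by the name of the read-out).
Compound 2, `Fc1cccc(Nc2n[nH]c3ccccc23)c1`, gives 18% in this assay.
Compound 3, `Fc1ccc2[nH]nc(Nc3cccc(Cl)c3)c2c1`, gives 49% in this assay.

Compound 3 holds the highest of the three numbers, though its gap to compound 1 is within the scatter; only compound 2 lies clearly lower. Compound 4, `COc1ccc2[nH]nc(Nc3cccc(Cl)c3)c2c1`, differs from compound 3 by methoxy in place of fluoro on an aromatic carbon. The step that bears most on this place is a number 7 percentage points higher from compound 1 to compound 3 (within the scatter), which shows that changing this position left the number within the scatter. The step of a number 24 percentage points lower from compound 1 to compound 2 (beyond the scatter) sits on the other ring and is less relevant. Going by the values given here, no measured pair shows methoxy at this place, so a step within the scatter in this assay is expected, giving an estimated a number 4 percentage points lower from compound 3 to compound 4 (within the scatter). For compound 4 the estimate is 45%, with a range from 25% to 65%.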

Compound 4, a percentage reported as inhibition, in the whole organism at one dose (the size of the read-out at that dose, not a potency): 75%
For compound 4 the middle estimate is 30 percentage points below the measured one, and the stated range ends below it.
By their numbers in this assay, from the lowest: compound 2; then compounds 1 and 3 (each within the scatter of the next); then compound 4.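

In this assay this place on the shared core proves sensitive to which group sits there: fluoro left the number within the scatter of hydrogen, yet methoxy in place of hydrogen brings a number 33 percentage points higher from compound 1 to compound 4 (beyond the scatter) on its own terms. Methoxy in place of fluoro likewise brings a number 26 percentage points higher from compound 3 to compound 4 (beyond the scatter) and so stands clearly apart from both smaller substituents. Nothing measured here explains why methoxy behaves differently from fluoro at this place.

As far as these compounds go, whether an ethoxy group or an amine at this place would raise the number as well remains open. So does whether methoxy would have the same effect on the core of compound 2, which carries fluoro instead of chloro on the other ring.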